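A Propyl Chain Added to a Fluorophenyl Triazole Ester

This account rests on a few compounds, and the source may have more. Where it says the series, first, only, none or still open, it means among the compounds named here.

Compound 1 `COC(=O)c1nc(C)n(-c2ccc(OC)cc2)n1` gives 9920 nM in a functional assay on NPC-TW01 cells (Homo sapiens) for inhibition, read by MTT assay, with a stated time of 72 h; a higher number here means a weaker inhibitor of growth, a lower number a stronger inhibitor of growth. Within the data shown here, compound 2 `COC(=O)c1nc(C)n(-c2ccc(F)cc2)n1` gives 15200 nM in this assay; the single measured step, a 1.5-fold higher number from compound 1 to compound 2 (0.19 log units; within the scatter), swaps one substituent on the aromatic ring for another. Among the measured compounds shown here, compound 2 thus has the larger of only two numbers, but compound 1 sits within the scatter of it, so the two cannot be told apart on these data.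

Compound 3 `CCCCc1nc(C(=O)OC)nn1-c1ccc(F)cc1` is built from compound 2 by the change (propyl in place of hydrogen on a saturated chain carbon bound to an aromatic carbon). For the measured compounds named here, no measured step touches this part of the molecule: the one step that exists concerns the aromatic substituent, not the chain on the core. There is therefore no basis for expecting a step beyond the scatter in either direction, only wide uncertainty. Compound 3 is expected to give 14000 nM, within the range 4000 nM to 50000 nM. That estimate corresponds to an expected 1.1-fold lower number from compound 2 to compound 3 (0.04 log units; within the scatter).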

Compound 3, concentration for 50% growth inhibition: > 100000 nM
Compound 3: only a limit was reported (the forecaster's own chance of this, stated with the estimate: 15%); middle value at least 7.1-fold (0.85 log units) away from the limit.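

Read as methyl to butyl on the shared core, the change of propyl in place of hydrogen on a saturated chain carbon bound to an aromatic carbon gives an at least 6.5-fold higher number from compound 2 to compound 3 (0.81 log units; beyond the scatter), so growth inhibition in this assay is clearly weakened. The earlier step, a 1.5-fold higher number from compound 1 to compound 2 (0.19 log units; within the scatter), showed no clear response to the aromatic substituent, whereas this chain position does respond, and the longer chain is not tolerated here. For compound 3 the reading is a limit and not a number: the limit of > 100000 nM in this assay, at which 1 of the 3 values shown sits.

As far as these compounds go, how much weaker compound 3 really is therefore stays open, since only the minimum size of the step can be read. Also open, from the compounds shown here alone, is whether an ethyl chain would already weaken growth inhibition, and whether an amine or a carboxylic acid at the end of the butyl chain would change the outcome.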